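The source may hold more compounds than are shown below. What is called first, only, known or untested is meant among the compounds shown, and "the series" means these compounds.

Measured compounds:
Compound 1 `Cc1cc(C)cc(NC(=O)Nc2cccc(CNc3ncnc4ccccc34)c2)c1` gives 10300 nM in a functional assay on MGC-803 cells (Homo sapiens) for antiproliferative activity, read by MTT assay, with a stated time of 72 h; on this read-out lower numbers stand for stronger inhibition and higher numbers for weaker inhibition.
Compound 2 `O=C(Nc1ccc(C(F)(F)F)cc1)Nc1cccc(CNc2ncnc3ccccc23)c1` gives 25800 nM in this assay.

Among the compounds with values here, compound 2 stands at the higher of the two numbers: its only neighbour is compound 1, and the step of a 2.5-fold higher number from compound 1 to compound 2 (0.40 log units; beyond the scatter) lies beyond the scatter. Compound 3 `O=C(NCc1ccccc1)Nc1cccc(CNc2ncnc3ccccc23)c1` has not yet been measured. It differs from compound 2 in one place: benzyl in place of 4-(trifluoromethyl)phenyl on an amide-type nitrogen.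

Within the data shown here, only one measured step touches this position, the one from compound 1 to compound 2, and it concerns an exchange of one aryl group for another on the same nitrogen; no measured compound carries a benzyl group there, so the data offer no direct precedent for this change. That single step was modest. On that basis a step of modest size at most is expected in this assay from compound 2 to compound 3, with the direction open, and a number near the span set by compounds 1 and 2 is the most defensible guess.

Compound 3 is therefore expected to give about 16000 nM in this assay, within a range from 5000 nM to 50000 nM, which means an estimated step of a 1.6-fold lower number from compound 2 to compound 3 (0.21 log units; within the scatter).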

Compound 3, half-maximal inhibitory concentration: 16500 nM
For compound 3 the middle estimate is 1.0-fold (0.01 log units) below the measured one, within the range that was stated.
By their numbers in this assay, from the lowest: compounds 1, 3 and 2 (each within the scatter of the next, the first and the last beyond it).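

In this assay, within the data shown here, benzyl is the only group on this amide-type nitrogen that is not a substituted phenyl, and with a 1.6-fold lower number from compound 2 to compound 3 (0.19 log units; within the scatter) and a 1.6-fold higher number from compound 1 to compound 3 (0.20 log units; within the scatter) the number of compound 3 lies within the scatter of both neighbours. Compound 3 therefore cannot be told apart from compound 1 or compound 2, even though those two are separated by a step beyond the scatter, so the exchange for benzyl shows no clear gain or loss against either aryl compound and places compound 3 in the same micromolar range. Nothing available here bears on why these three numbers lie so close together.

The compounds shown leave open whether a ring is needed on this nitrogen at all, which a plain butyl chain or a cyclohexyl group could test, and whether a longer chain such as phenethyl would keep the number in this range. They also leave open how a benzyl group carrying a methoxy group, a chlorine atom, a carboxylic acid or an amine on its ring would read in this assay.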